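A few compounds are considered here, and "the series" means these few. Any claim that something is new, unique, unknown or untested is made for them only; others in the source may bear on it.

Of the compounds shown here, three sharing one core have been measured in a functional assay on KB-V1 cells (Homo sapiens) for cytotoxicity, read by MTT assay, with a stated time of 72 h; on this read-out lower numbers stand for stronger inhibition and higher numbers for weaker inhibition. In this test, compound 1 `CN(C)c1ccc(NC(=S)N/N=C2\C(=O)Nc3ccccc32)cc1` gives 2320 nM, compound 2 `O=C1Nc2ccccc2/C1=N/NC(=S)Nc1ccc(Oc2ccccc2)cc1` gives 1670 nM and compound 3 `CC(C)(C)c1ccc(NC(=S)N/N=C2\C(=O)Nc3ccccc32)cc1` gives 710 nM, the lowest number of the three. Compound 4 `CCCC1CCC(c2ccc(NC(=S)N/N=C3\C(=O)Nc4ccccc43)cc2)CC1` departs from compound 3 at one place, with 4-propylcyclohexyl in place of tert-butyl on an aromatic carbon.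

Two measured steps arrive at the tert-butyl group and so bear on this change: a 3.3-fold lower number from compound 1 to compound 3 (0.51 log units; beyond the scatter) and a 2.4-fold lower number from compound 2 to compound 3 (0.37 log units; beyond the scatter). Both are modest. The remaining step, a 1.4-fold lower number from compound 1 to compound 2 (0.14 log units; within the scatter), lies within the scatter. Going by the values given here, no measured compound carries a non-aromatic ring at this place, so the direction rests on weak evidence. In this assay, a modest move towards a lower number is expected, though a step within the scatter would be no surprise. The estimated change is a 1.6-fold lower number from compound 3 to compound 4 (0.20 log units; within the scatter). The expected value for compound 4 is 450 nM, within an estimated range of 170 nM to 1200 nM.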

Compound 4, half-maximal inhibitory concentration: 11000 nM
Compound 4: middle estimate off by 24-fold (1.39 log units), on the low side; measured number outside the range, above it.
By their numbers in this assay, from the lowest: compound 3; then compounds 2 and 1 (each within the scatter of the next); then compound 4.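

In this assay, the earlier changes among dimethylamino, phenoxy and tert-butyl on this aromatic carbon gave steps that were modest or within the scatter, so they suggested a position that moves the number only a little. The 4-propylcyclohexyl group shows otherwise, with a 15-fold higher number from compound 3 to compound 4 (1.19 log units; beyond the scatter) as the largest step seen here and the first away from tert-butyl towards weaker inhibition. The same group also stands clear of the other two substituents, with a 6.6-fold higher number from compound 2 to compound 4 (0.82 log units; beyond the scatter) and a 4.7-fold higher number from compound 1 to compound 4 (0.68 log units; beyond the scatter) placing compound 4 as the weakest of the four, and no measurement at hand accounts for this.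

The compounds shown leave open whether the six-membered non-aromatic ring or the propyl chain on it carries the change. A plain cyclohexyl group or a straight butyl chain at this place would bear on that.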